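Difluoromethoxy in Place of Trifluoromethyl on a Shared Core

The source may report more compounds than this note shows. Statements on the series, on what has been measured and on what is new or still open speak of the compounds shown alone.

Compound 1 `Nc1cnc(-c2cc(N3C[C@@H]4C[C@H]3CO4)nc(N3CC4CC3C4)n2)cn1` was measured in an assay on Sf21 cells for inhibition of mitogen-activated protein kinase kinase kinase 13 (Homo sapiens), read by HTRF, with a stated time of 1.5 h (on this read-out lower numbers stand for stronger inhibition and higher numbers for weaker inhibition), and gave 247 nM. Compound 2 `Nc1ncc(-c2cc(N3C[C@@H]4C[C@H]3CO4)nc(N3CC4CC3C4)n2)nc1C(F)(F)F` carries a trifluoromethyl on an aromatic carbon where compound 1 has hydrogen, and in this assay compound 2 gave 149 nM; the step of a 1.7-fold lower number from compound 1 to compound 2 (0.22 log units; within the scatter). On the two numbers shown, compound 2 is therefore not separated from compound 1 beyond the scatter. Compound 3 `Nc1ncc(-c2cc(N3C[C@@H]4C[C@H]3CO4)nc(N3CC4CC3C4)n2)nc1OC(F)F` differs from compound 2 by difluoromethoxy in place of trifluoromethyl on an aromatic carbon. For the measured compounds named here, the only measured step, a 1.7-fold lower number from compound 1 to compound 2 (0.22 log units; within the scatter), concerns a different change at the same aromatic carbon and stayed within the scatter, so no measured step speaks to swapping one four-heavy-atom group for another there. The step of a 1.2-fold higher number from compound 2 to compound 3 (0.08 log units; within the scatter) is therefore expected to stay within the scatter. Compound 3 is estimated at 180 nM in this assay, with a range from 60 nM to 540 nM.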

Compound 3, half-maximal inhibitory concentration: 7 nM
For compound 3 the middle estimate is 26-fold (1.41 log units) above the measured one; measured number below the stated range.
By their numbers in this assay, from the lowest: compound 3; then compounds 2 and 1 (each within the scatter of the next).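

At this aromatic carbon, next to the ring nitrogen and ortho to an amino group, the choice of substituent can matter a great deal in this assay: exchanging trifluoromethyl for difluoromethoxy gives a 21-fold lower number from compound 2 to compound 3 (1.33 log units; beyond the scatter), although both groups count the same number of heavy atoms. Trifluoromethyl had not separated itself from hydrogen at this carbon, whereas difluoromethoxy does, with a 35-fold lower number from compound 1 to compound 3 (1.55 log units; beyond the scatter), so the position is not indifferent to what it carries. Nothing available on these compounds accounts for the gain, beyond the counted difference of oxygen for one fluorine and the one hydrogen-bond acceptor that enters.

The compounds shown leave open whether the low number follows the oxygen or the fluorines, since neither methoxy nor ethoxy appears at this carbon. They also leave open how an amine there would compare.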